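Lengthening the chain from compound 3 to compound 4

This account rests on a few compounds, and the source may have more. Where it says the series, first, only, none or still open, it means among the compounds named here.

Values so far in a functional assay on MGC-803 cells (Homo sapiens) for antiproliferative activity, read by MTT assay, with a stated time of 48 h; a higher number here means a weaker inhibitor, a lower number a stronger inhibitor
compound 1 `CCCCCCCCCCn1cc(COC[C@@H]2OC[C@H](N)[C@@H]2O)nn1` gives 8780 nM
compound 2 `CCCCCCCn1cc(COC[C@@H]2OC[C@H](N)[C@H]2O)nn1` gives > 128000 nM as a limit of the assay
compound 3 `CCCCCCCCCCn1cc(COC[C@@H]2OC[C@H](N)[C@H]2O)nn1` gives 57400 nM

Of the two exact numbers, the higher belongs to compound 3, and the change in configuration alone gives a 6.5-fold higher number from compound 1 to compound 3 (0.82 log units; beyond the scatter) in this assay. Compound 4 `CCCCCCCCCCCCCCCCCCn1cc(COC[C@@H]2OC[C@H](N)[C@H]2O)nn1` differs from compound 3 by octyl in place of hydrogen on a saturated chain carbon, ten or more bonds along the chain from an aromatic nitrogen. Going by the values given here, the step that bears on this is the only chain step measured, an at least 2.2-fold lower number from compound 2 to compound 3 (0.34 log units; beyond the scatter), and it rests on a limit. On that step from compound 2, a further modest fall in the number is expected, though this extension is much longer. The estimated step is a 2.3-fold lower number from compound 3 to compound 4 (0.36 log units; beyond the scatter) in this assay, with the direction less certain than its size suggests. Compound 4 is expected near 25000 nM, with an estimated range from 7000 nM to 100000 nM in this assay when measured.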

Compound 4, half-maximal inhibitory concentration: 3110 nM
Estimate against measurement, compound 4: 8.0-fold (0.91 log units) above; measured number outside the range, below it.
By their numbers in this assay, from the lowest: compound 4; then compound 1; then compound 3. At a limit, above all of these: compound 2.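

In this assay, the number keeps falling as the chain grows, and octyl in place of hydrogen on a saturated chain carbon gives an 18-fold lower number from compound 3 to compound 4 (1.27 log units; beyond the scatter). Over the full length, undecyl in place of hydrogen gives an at least 41-fold lower number from compound 2 to compound 4 (1.61 log units; beyond the scatter). That second step is bounded by a limit of the assay for compound 2: the limit of > 128000 nM in this assay, at which 1 of the 4 values shown sits.

On these data alone, whether a still longer chain lowers the number further remains open, as does the effect of a terminal amine or carboxylic acid on the chain. Also open, as far as these compounds go, is whether the same octyl extension on compound 1 would give a similar step.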